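The source may hold more compounds than are shown below. What is called first, only, known or untested is meant among the compounds shown, and "the series" means these compounds.

In a functional assay on K562 cells (Homo sapiens) for cytotoxicity, read by trypan blue exclusion, with a stated time of 96 h (on this read-out lower numbers stand for stronger inhibition and higher numbers for weaker inhibition), compound 1 `COc1ccc(CS(=O)(=O)/C=C/c2c(OC)cc(O)cc2OC)cc1N` gives 300 nM and compound 2 `COC(=O)[C@H](C)Nc1cc(CS(=O)(=O)/C=C/c2c(OC)cc(OC)cc2OC)ccc1OC` gives 200 nM, a gap within the scatter of repeated measurements. Compound 3 `COC(=O)C(Nc1cc(CS(=O)(=O)/C=C/c2c(OC)cc(OC)cc2OC)ccc1OC)c1ccc(Br)cc1` differs from compound 2 at one place, with (4-bromophenyl)(methoxycarbonyl)methyl in place of 1-(methoxycarbonyl)ethyl on a nitrogen on an aromatic ring. For the measured compounds named here, no measured pair here shows what such a swap does, so the forecast stays cautious. A small rise in the number is expected, an estimated 2.0-fold higher number from compound 2 to compound 3 (0.30 log units; within the scatter). For compound 3 the estimated value is 400 nM, with an expected range of 100 nM to 1600 nM.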

Compound 3, half-maximal inhibitory concentration: 200 nM
The estimate for compound 3 lay 2.0-fold (0.30 log units) above the measured number; low and high end bracket the measured number.
By their numbers in this assay, from the lowest: compounds 2, 3 and 1 (each within the scatter of the next).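

Putting (4-bromophenyl)(methoxycarbonyl)methyl in place of 1-(methoxycarbonyl)ethyl on the nitrogen gives no change at the digits printed from compound 2 to compound 3 (within the scatter) in this assay as the measured result. This position on the nitrogen therefore accepts a group of 12 heavy atoms with a six-membered aromatic ring, where 6 heavy atoms with no ring stood before, without a shift beyond the scatter. No measurement shown accounts for this tolerance. Still open, from the compounds shown here alone, is whether a carboxylic acid in place of the methoxycarbonyl would leave the number unchanged. The same holds for a longer carbon chain on this nitrogen.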